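The source may hold more compounds than are shown below. What is called first, only, known or untested is meant among the compounds shown, and "the series" means these compounds.

Measured compounds:
- compound 1 `COc1cc(/C=C/C(=O)OCCCCCCO[N+](=O)[O-])ccc1O`: 32100 nM
- compound 2 `O=C(/C=C/c1ccc(OCCCCCO[N+](=O)[O-])c(O)c1)OCCCCCO[N+](=O)[O-]`: > 50000 nM (a limit of the assay, not a number)

The series was tested in a functional assay on NCI-H157 cells (Homo sapiens) for cytotoxicity, read by resazurin assay, with a stated time of 72 h; a lower number here means a stronger inhibitor, a higher number a weaker inhibitor. Among the measured compounds shown here, in it, compound 1 gives 32100 nM, and this is the only actual number available. Compound 2 reached only a limit of the assay, > 50000 nM. The position of compound 1 therefore cannot be judged against a second number, and nothing yet shows how the potency in this assay responds to a single structural change.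

The next compound is compound 3 `COc1cc(/C=C/C(=O)OCCCCCO[N+](=O)[O-])ccc1O`. It differs from compound 1 at the end of the ester chain: nitrooxy in place of (nitrooxy)methyl on a saturated chain carbon, five bonds along the chain from an oxygen next to a carbonyl group. In words, nitrooxy stands in place of (nitrooxy)methyl on a saturated chain carbon, five bonds along the chain from an oxygen next to a carbonyl group. The rest of the molecule is unchanged.

For the measured compounds named here, no measured pair gives the size of such a step, so only a small change is expected, with none beyond the usual scatter and no firm direction. The expected step is a 1.1-fold higher number from compound 1 to compound 3 (0.04 log units; within the scatter). For compound 3 the estimated value is 35000 nM, with an expected range from 18000 nM to 50000 nM.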

Compound 3, half-maximal inhibitory concentration: 13400 nM
Compound 3: middle estimate off by 2.6-fold (0.42 log units), on the high side, and the stated range ends above it.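

Through the exchange of (nitrooxy)methyl for nitrooxy on a saturated chain carbon, five bonds along the chain from an oxygen next to a carbonyl group, this assay gives its first readable step: a 2.4-fold lower number from compound 1 to compound 3 (0.38 log units; beyond the scatter). This shows that the number responds to a change at this position, and that the shorter chain goes with the lower number, though the step is modest and rests on this one pair. The leaving and entering groups have the same counts of hydrogen-bond donors and acceptors, so the difference printed between them is the chain carbon, while compound 2 stands only at a limit of the assay and adds no number to this comparison: the limit of > 50000 nM in this assay, at which 1 of the 3 values shown sits.

A single step cannot show whether the trend continues along the chain, since one pair gives no sign of whether a still shorter chain or a longer chain would lower or raise the number. As far as these compounds go, it also remains open whether the nitrooxy group itself matters at this place, which a comparison with an amine or a carboxylic acid at the same chain carbon could address.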